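A heavier chain on the shared core

This account rests on a few compounds, and the source may have more. Where it says the series, first, only, none or still open, it means among the compounds named here.

Compound 2 `CCCc1nnc2sc(-c3cccc(F)c3)nn12` stands highest of the two numbers measured in an assay for inhibition of histone-lysine N-methyltransferase, H3 lysine-79 specific (Homo sapiens), with stated times of 15 min and 120 min, tested at 50 uM (a lower number here means less inhibition, a higher number more inhibition at the concentration tested (going by the name of the read-out)), where compound 2 gives 35%. Its nearest neighbour, compound 1 `Fc1cccc(-c2nn3c(CCc4ccccc4)nnc3s2)c1`, gives 18% in this assay. Compound 3 `Fc1cccc(-c2nn3c(CSc4ccccc4)nnc3s2)c1` carries phenylsulfanyl in place of ethyl on a saturated chain carbon bound to an aromatic carbon. For the measured compounds named here, the one measured step that bears on this change is a number 17 percentage points higher from compound 1 to compound 2 (beyond the scatter), in which a phenyl left the chain and inhibition rose. Compound 3 returns a phenyl-bearing group to that chain, so a fall of comparable size is expected, a number 13 percentage points lower from compound 2 to compound 3 (beyond the scatter). Compound 3 is therefore estimated at 22% in this assay, with a range from 5% to 40%.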

Compound 3, a percentage reported as inhibition, at one concentration (the size of the read-out at that concentration, not a potency): 21%
Estimate against measurement, compound 3: 1 percentage points above; the range from low to high includes it.
By their numbers in this assay, from the lowest: compounds 1 and 3 (each within the scatter of the next); then compound 2.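

In this assay, phenylsulfanyl in place of ethyl on a saturated chain carbon bound to an aromatic carbon gives a number 14 percentage points lower from compound 2 to compound 3 (beyond the scatter), so a second phenyl-bearing chain also reads below the short chain of compound 2. Phenylsulfanyl in place of benzyl gives a number 3 percentage points higher from compound 1 to compound 3 (within the scatter), so the sulfur in the chain brings no difference that this read-out can separate from the all-carbon chain. Nothing available explains these numbers.

The compounds shown leave open how an amine or a carboxylic acid on this chain carbon would read. They also leave open how a longer chain without a ring would compare with compound 2.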